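A few compounds are considered here, and "the series" means these few. Any claim that something is new, unique, unknown or untested is made for them only; others in the source may bear on it.

The series rests on a shared core carrying a trifluoromethyl group and a urea link to a second aromatic ring. Compound 1 `COc1ccc(-c2cc(NC(=O)Nc3ccncc3)cc(C(F)(F)F)c2)cn1` carries a 6-methoxypyridin-3-yl group and a pyridin-4-yl urea; in a functional assay on A549 cells (Homo sapiens) for inhibition, read by MTT assay, with a stated time of 48 h (on this read-out higher numbers stand for weaker inhibition and lower numbers for stronger inhibition), compound 1 gives 276000 nM. Compound 2 `O=C(Nc1ccncc1)Nc1cc(-c2cncnc2)cc(C(F)(F)F)c1` differs from it in one place, namely (pyrimidin-5-yl in place of 6-methoxypyridin-3-yl on an aromatic carbon), and in this assay compound 2 gives 2420 nM. That single exchange makes a 110-fold lower number from compound 1 to compound 2 (2.06 log units; beyond the scatter).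

Compound 3 `COc1ccc(-c2cc(NC(=O)Nc3nccs3)cc(C(F)(F)F)c2)cn1` keeps the 6-methoxypyridin-3-yl group of compound 1 but differs at the urea, where (1,3-thiazol-2-yl in place of pyridin-4-yl on an amide-type nitrogen). In this assay, for the measured compounds named here, compound 3 gives "not determined" (no result reported), so no step from compound 1 to compound 3 can be stated.

Compound 4 `O=C(Nc1cc(-c2cncnc2)cc(C(F)(F)F)c1)Nc1nccs1` has not yet been measured. It stands to compound 3 as compound 2 stands to compound 1: pyrimidin-5-yl in place of 6-methoxypyridin-3-yl on an aromatic carbon. Going by the values given here, the change is the same kind of change as the one from compound 1 to compound 2, though the surroundings are described differently, being meta to a large group in the first case and meta to a ((1,3-thiazol-2-yl)carbamoyl)amino group in the second. The measured exchange gave a 110-fold lower number from compound 1 to compound 2 (2.06 log units; beyond the scatter). A step of a similar size is therefore expected from compound 3 to compound 4, although compound 3 itself carries no number to anchor it. Compound 4 is expected to give about 3000 nM in this assay, with a likely range from 500 nM to 30000 nM. This expectation rests on compound 2 and its value 2420 nM.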

Compound 4, half-maximal inhibitory concentration: 18300 nM
Beside the measured number, compound 4's estimate is 6.1-fold (0.79 log units) below it; the measured number falls inside the stated range.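

In this assay, for the compounds shown here, the one new step that can be read lies at the urea and not at the exchanged ring: with the pyrimidin-5-yl group held constant, 1,3-thiazol-2-yl in place of pyridin-4-yl on an amide-type nitrogen gives a 7.6-fold higher number from compound 2 to compound 4 (0.88 log units; beyond the scatter). This shows that the urea partner changes the read-out on this core, but it does not show whether the exchange that gave a 110-fold lower number from compound 1 to compound 2 (2.06 log units; beyond the scatter) carries over to the 1,3-thiazol-2-yl urea, as the step from compound 3 to compound 4 cannot be read without a result for compound 3. The data offer no measurement that would explain the higher number of compound 4.

From the compounds shown here alone, it remains open whether the pyrimidin-5-yl exchange has any consistent effect across urea partners, as it is read on the pyridin-4-yl urea alone. Going by these compounds, it is also open how an amine or a carboxylic acid in place of the methoxy group of the 6-methoxypyridin-3-yl group would behave on either urea.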